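The source may report more compounds than this note shows. Statements on the series, on what has been measured and on what is new or still open speak of the compounds shown alone.

So far, two compounds have been tested in a functional assay on DU-145 cells (Homo sapiens) for inhibition, read by MTT assay, with stated times of 18 h and 4 h; on this read-out higher numbers stand for weaker inhibition and lower numbers for stronger inhibition. Compound 1 (`CCCCCCCCCCOP(=O)(O)OCCSC(=S)N1CCCCC1`) gives 29300 nM, and compound 2 (`CCCCCCOP(=O)(O)OCCSC(=S)N1CCCCCC1`) gives 77400 nM. Compound 2 therefore has the higher of the two numbers, meaning the weaker inhibition, and the gap lies beyond the usual scatter. These two compounds differ in more than one place, so their gap cannot be tied to any single change. Compound 3 (`CCCCCCOP(=O)(O)OCCSC(=S)N1CCCCC1`) differs from compound 2 in one place: it has piperidin-1-yl in place of azepan-1-yl on a thiocarbonyl carbon, (piperidin-1-yl in place of azepan-1-yl on a thiocarbonyl carbon). Within the data shown here, no measured pair shows this change alone, so no step beyond the scatter is expected in this assay. The estimated step is small, a 1.1-fold lower number from compound 2 to compound 3 (0.04 log units; within the scatter). For compound 3, the expected value is 70000 nM, with an estimated range of 35000 nM to 140000 nM.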

Compound 3, half-maximal inhibitory concentration: > 100000 nM
Compound 3: no number, only a limit (the forecaster's own chance of this, stated with the estimate: 10%); middle value at least 1.4-fold (0.15 log units) away from the limit.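

In this assay, compound 3 gives a limit and not a number: the limit of > 100000 nM in this assay, at which 1 of the 3 values shown sits.

Placing piperidin-1-yl instead of azepan-1-yl on the thiocarbonyl carbon gives an at least 1.2-fold higher number from compound 2 to compound 3 (0.11 log units; that floor lies within the scatter), so this floor alone does not show that the change of ring matters. Placing hydrogen instead of butyl on the saturated chain carbon gives an at least 3.4-fold higher number from compound 1 to compound 3 (0.53 log units; beyond the scatter), which is the first single-place comparison to show a difference beyond the scatter, with weaker inhibition for the compound without the butyl.

Going by these compounds, the true size of both steps stays open, since each rests on a limit rather than on a measured number for compound 3. Also open, on these data alone, is how a longer chain than that of compound 1, or a morpholin-4-yl group on the thiocarbonyl carbon, would read.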